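Chloro-to-hydrogen step on the fused core of compound 2

The compounds below may be only part of what the source reports. "The series", "measured", "known", "first", "only" and "open" are said of these compounds alone.

Measured so far:
compound 1 `ClCc1ccc(Cn2cnc3c(Cl)ncnc32)cc1` gives 3980 nM in a functional assay on 786-0 cells (Homo sapiens) for cytotoxicity, read by sulforhodamine B assay, with a stated time of 48 h; a higher number here means a weaker inhibitor of growth, a lower number a stronger inhibitor of growth
compound 2 `ClCc1ccccc1Cn1cnc2c(Cl)nc(Cl)nc21` gives 3470 nM in this assay

Compound 2 holds the lowest of the two numbers in this assay, but its nearest neighbour, compound 1, lies within the scatter, so the two cannot be ordered. Compound 3 `ClCc1ccccc1Cn1cnc2c(Cl)ncnc21` is not yet measured. It differs from compound 2 by hydrogen in place of chloro on an aromatic carbon. For the measured compounds named here, no measured pair isolates this change, so the size of the step in this assay is open. Compound 1, which lacks this chloro while also carrying its chloromethyl group elsewhere, sits within the scatter of compound 2, which gives no sign of a large effect. The expected step from compound 2 to compound 3 is therefore a 1.2-fold higher number from compound 2 to compound 3 (0.06 log units; within the scatter), within the scatter, in no fixed direction. Compound 3 is estimated at 4000 nM, expected between 1500 nM and 11000 nM.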

Compound 3, concentration for total growth inhibition: 38000 nM
Beside the measured number, compound 3's estimate is 9.5-fold (0.98 log units) below it, and the stated range ends below it.
By their numbers in this assay, from the lowest: compounds 2 and 1 (each within the scatter of the next); then compound 3.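

In this assay, hydrogen in place of chloro on the aromatic carbon between two ring nitrogen atoms gives an 11-fold higher number from compound 2 to compound 3 (1.04 log units; beyond the scatter) and shows that, with this placement of the chloromethyl group, the chloro at this position is far from indifferent. Compound 1 also lacks this chloro yet gives 3980 nM against 38000 nM for compound 3, so the missing chloro alone does not set the number, and the two differ only in where the chloromethyl group sits. No supporting data bear on why this step is so large.

Still open, as far as these compounds go, is whether an amine or a methoxy group on this carbon would keep the number near that of compound 2. Also open, from the compounds shown here alone, is how large the chloro step is with the chloromethyl group placed as in compound 1.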